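Solubility of a Pyridinium Ketone after Benzyl Ester Substitution

A few compounds are considered here, and "the series" means these few. Any claim that something is new, unique, unknown or untested is made for them only; others in the source may bear on it.

Of the compounds shown here, three have been measured in a physicochemical assay for solubility; a lower number here means a less soluble compound, a higher number a more soluble compound. Compound 1 `COc1cc2cc(C(=O)CC(OC)C3CC[N+](C)(Cc4ccccc4)CC3)sc2cc1OC` gives 1500 ug/mL, and compound 2 `COc1cc2cc(C=C3CC[N+](C)(Cc4ccccc4)CC3)sc2cc1OC` gives 1000 ug/mL. Compound 3 `CCC[n+]1ccc(CCC(=O)c2cc3cc(OC)c(OC)cc3s2)cc1` gives 16000 ug/mL, the highest of the three numbers: its gap to compound 1 is beyond the scatter, and its gap to compound 2 is wider still. Compound 4 `COC(=O)c1ccc(C[n+]2ccc(CCC(=O)c3cc4cc(OC)c(OC)cc4s3)cc2)cc1` has not yet been measured. It differs from compound 3 in one place: 4-(methoxycarbonyl)phenyl in place of ethyl on a saturated chain carbon bound to an aromatic nitrogen. Within the data shown here, no single-change step between measured compounds exists to calibrate this change, so the expectation rests on the spread of the three numbers. The added group is large and the two compounds that sit well below compound 3 both carry a charged nitrogen with a bulkier substituent, so compound 4 is expected to fall clearly below compound 3, by a step of roughly an 8.0-fold lower number from compound 3 to compound 4 (0.90 log units; beyond the scatter), beyond the scatter. The estimate for compound 4 in this assay is 2000 ug/mL, with a likely range from 500 ug/mL to 8000 ug/mL.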

Compound 4, solubility: 3500 ug/mL
Beside the measured number, compound 4's estimate is 1.8-fold (0.24 log units) below it; the measured number falls inside the stated range.
By their numbers in this assay, from the lowest: compounds 2 and 1 (each within the scatter of the next); then compound 4; then compound 3.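

In this assay, among these compounds, replacing ethyl with 4-(methoxycarbonyl)phenyl on a saturated chain carbon bound to an aromatic nitrogen gives the first single-change step of this set, a 4.6-fold lower number from compound 3 to compound 4 (0.66 log units; beyond the scatter), so this position does respond to the change. The step lies beyond the scatter but is modest: with 10 heavy atoms and a six-membered aromatic ring entering where 2 heavy atoms left, compound 4 still gives 3500 ug/mL in this assay.

The compounds shown leave open whether the aromatic ring or the ester goes with the lower number; a plain benzyl group, or a carboxylic acid in place of the methyl ester, would separate the two. No measurement is available that bears on the reason for this step.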